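Cyclohexyl for 3-Methoxyphenyl on the Ring Amide Nitrogen

The source may report more compounds than this note shows. Statements on the series, on what has been measured and on what is new or still open speak of the compounds shown alone.

Measured so far:
compound 1 `O=C1COc2ccc(-c3cccc(NS(=O)(=O)c4ccc(F)cc4)c3)cc2N1c1ccccc1` — in a functional assay on HepG2 cells (Homo sapiens) for antiproliferative activity, read by MTT assay, with a stated time of 72 h (a higher number here means a weaker inhibitor, a lower number a stronger inhibitor), compound 1 gives 30300 nM
compound 2 `COc1cccc(N2C(=O)COc3ccc(-c4cnc(Cl)c(NS(=O)(=O)c5ccc(F)cc5)c4)cc32)c1` — in this assay compound 2 gives only the limit > 40000 nM
compound 3 `O=C1COc2ccc(-c3cnc4ccccc4c3)cc2N1c1ccc(Cl)cc1` — in this assay compound 3 gives 32700 nM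

Compound 2 stands at the edge of what this assay reports: its > 40000 nM is a limit of the assay, not a number, as the limit of > 40000 nM in this assay, at which 1 of the 3 values shown sits, records. Compounds 1 and 3 sit within the usual scatter of each other, so no order between them is drawn. Among the compounds with values here, no pair of measured compounds differs in one place only, so no measured step exists to lean on.

Compound 4 `O=C1COc2ccc(-c3cnc(Cl)c(NS(=O)(=O)c4ccc(F)cc4)c3)cc2N1C1CCCCC1` is next to be run in this assay; it differs from compound 2 by cyclohexyl in place of 3-methoxyphenyl on an amide-type nitrogen in a ring. Within the data shown here, with every value so far weak or at the limit, the step of a number no higher from compound 2 to compound 4 (the limit leaves the size open) is expected to stay within the scatter, in no particular direction. Compound 4 is therefore estimated at 40000 nM in this assay, ranging from 15000 nM to 90000 nM, with a fair chance that only a limit is reported again.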

Compound 4, half-maximal inhibitory concentration: > 40000 nM
Compound 4: a limit, no number (the forecaster's own chance of this, stated with the estimate: 50%); the middle value lies on the limit itself.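

In this assay, compound 2 and compound 4 both report only a limit, not a number, and no step between them can be read: the limit of > 40000 nM in this assay, at which 2 of the 4 values shown sit.

On these data alone, whether cyclohexyl in place of 3-methoxyphenyl on an amide-type nitrogen in a ring changes the read-out at all remains open.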